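A Further ((Ethoxycarbonyl)carbonyl)amino Arm on a Seven-Membered Ring

A few compounds are considered here, and "the series" means these few. Any claim that something is new, unique, unknown or untested is made for them only; others in the source may bear on it.

Compound 1 `CCOC(=O)C(=O)Nc1cccccc1=O` was tested in a functional assay on the whole organism (strain Sprague-Dawley CD) for inhibition, with Rattus norvegicus as the target, read by paw edema, at a dose of 30 mg/kg by the intraperitoneal route (on this read-out lower numbers stand for a weaker effect and higher numbers for a stronger effect at the one dose given), where compound 1 gives 84%, the higher of the two values measured. Within the data shown here, compound 2 `CCOC(=O)C(=O)Nc1ccccc(-c2ccccc2)c1=O` gives 72% in this assay; the only measured step, a number 12 percentage points lower from compound 1 to compound 2 (beyond the scatter), comes from a group added to the shared core. Compound 3 `CCOC(=O)C(=O)Nc1ccc(NC(=O)C(=O)OCC)c(=O)cc1` differs from compound 1 thus: ((ethoxycarbonyl)carbonyl)amino in place of hydrogen on an aromatic carbon. Because a number 12 percentage points lower from compound 1 to compound 2 (beyond the scatter) was a modest fall after a group entered the core, a similar small drop or none beyond the scatter is expected in this assay, a step of a number 10 percentage points lower from compound 1 to compound 3 (within the scatter). Compound 3 is therefore estimated at 74%, within 58% to 88%.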

Compound 3, a percentage reported as inhibition, in the whole organism at one dose (the size of the read-out at that dose, not a potency): 84%
Estimate against measurement, compound 3: 10 percentage points below; the range from low to high includes it.
By their numbers in this assay, from the lowest: compound 2; then compounds 1 and 3 (each within the scatter of the next).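

In this assay, placing ((ethoxycarbonyl)carbonyl)amino on the aromatic carbon three ring bonds from the existing arm gives no change at the digits printed from compound 1 to compound 3 (within the scatter). The earlier step showed a group added to the shared core lowering the number, whereas this one shows that an added group of 8 heavy atoms need not do so. No evidence here accounts for this result. As far as these compounds go, whether a simple amine or a carboxylic acid at this position would also keep the effect remains open. So does whether either compound would stay level at other doses.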